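The source may report more compounds than this note shows. Statements on the series, on what has been measured and on what is new or still open speak of the compounds shown alone.

Measured compounds:
Compound 1 `Cn1nc(-c2ccnc(Nc3cccc([N+](=O)[O-])c3)n2)c2ccccc21`; in a functional assay on MCF7 cells (Homo sapiens) for antiproliferative activity, read by MTT assay, with a stated time of 72 h (a lower number here means a stronger inhibitor of growth, a higher number a weaker inhibitor of growth), compound 1 gives 580 nM.
Compound 2 `Cn1nc(-c2ccnc(Nc3cccc(S(N)(=O)=O)c3)n2)c2ccccc21`; in this assay compound 2 gives 2270 nM.
Compound 3 `CCn1nc(-c2ccnc(Nc3ccc(S(N)(=O)=O)cc3)n2)c2ccccc21`; in this assay compound 3 gives 2280 nM.

Compound 2 and compound 3 carry the same sulfamoyl group but on different cores; the difference between the two cores is not broken down here. Their values in this assay lie within the scatter of each other, so nothing is read from that pair.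

Compound 1 differs from compound 2 in one place: nitro in place of sulfamoyl on an aromatic carbon. Within the data shown here, that exchange gave a 3.9-fold lower number from compound 2 to compound 1 (0.59 log units; beyond the scatter), the only step in the set that lies beyond the scatter.

Compound 4 `CCn1nc(-c2ccnc(Nc3ccc([N+](=O)[O-])cc3)n2)c2ccccc21` has not been measured in this assay. It differs from compound 3 by nitro in place of sulfamoyl on an aromatic carbon. Among the measured compounds shown here, this is the same kind of change as the one from compound 2 to compound 1, not the same change: in compound 1 the nitro stands meta to a large group, in compound 4 it stands para to a large group. With a single earlier instance, and that on a different core and at a different place, the size of the next step is uncertain. The expectation for compound 4 is nevertheless a step of a 3.3-fold lower number from compound 3 to compound 4 (0.51 log units; beyond the scatter), resting on the earlier 3.9-fold lower number from compound 2 to compound 1 (0.59 log units; beyond the scatter) and on compound 3 giving 2280 nM. Compound 4 is therefore estimated at 700 nM in this assay, expected to fall between 300 nM and 1700 nM.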

Compound 4, concentration for 50% growth inhibition: 24000 nM
Beside the measured number, compound 4's estimate is 34-fold (1.54 log units) below it, and the stated range ends below it.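

In this assay, nitro in place of sulfamoyl on an aromatic carbon gives an 11-fold higher number from compound 3 to compound 4 (1.02 log units; beyond the scatter), and the change therefore does not carry over from one core to the other in either size or direction: the same change on two cores in this assay, a 3.9-fold lower number (0.59 log units; beyond the scatter) from compound 2 to compound 1 and an 11-fold higher number (1.02 log units; beyond the scatter) from compound 3 to compound 4, 41-fold (1.61 log units) apart, beyond the scatter of two such steps. This shows that a step measured on one core of this series is a poor guide to the same exchange on the other, at least for this pair of compounds. It does not show what drives the reversal: the two pairs differ both in the core and in where the exchanged group stands, para to a large group in compound 4, and one pair of each kind cannot separate these two differences.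

The compounds shown leave open how nitro and sulfamoyl compare when each stands para to a large group on the core of compound 1, and when each stands in the place it has in compound 1 on the core of compound 4; such pairs would split core from place. Also open, as far as these compounds go, is whether another group at this place, such as an amine or a carboxylic acid, would follow the nitro or the sulfamoyl compounds on either core.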